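Amide Nitrogen Substituent Change in the Urea Series

A few compounds are considered here, and "the series" means these few. Any claim that something is new, unique, unknown or untested is made for them only; others in the source may bear on it.

Measured:
compound 1 `CC(NC(=O)c1cccc(-c2ccc(NC(=O)Nc3ccc(Cl)c(C(F)(F)F)c3)cc2)c1)c1ccccc1` — 5670 nM
compound 2 `CC(NC(=O)CCc1ccc(NC(=O)Nc2ccc(Cl)c(C(F)(F)F)c2)cc1)c1ccccc1` — > 50000 nM

For the measured compounds named here, in a functional assay on HepG2 cells (Homo sapiens) for inhibition, read by MTT assay, with a stated time of 120 h (on this read-out higher numbers stand for weaker inhibition and lower numbers for stronger inhibition), compound 1 holds the only number recorded. Compound 2 sits at a limit of the assay, as the limit of > 50000 nM in this assay, at which 1 of the 2 values shown sits, shows. Compound 3 `CNC(=O)c1cccc(-c2ccc(NC(=O)Nc3ccc(Cl)c(C(F)(F)F)c3)cc2)c1` differs from compound 1 by methyl in place of 1-phenylethyl on an amide-type nitrogen. Going by the values given here, no measured pair covers this change, so the expectation rests on compound 1 alone. A loss of potency is expected, a 2.6-fold higher number from compound 1 to compound 3 (0.42 log units; beyond the scatter), beyond the usual scatter. Compound 3 is estimated at 15000 nM, with a range from 4000 nM to 50000 nM.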

Compound 3, half-maximal inhibitory concentration: 37100 nM
Estimate against measurement, compound 3: 2.5-fold (0.39 log units) below; the range from low to high includes it.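

Methyl in place of 1-phenylethyl on the amide-type nitrogen gives a 6.5-fold higher number from compound 1 to compound 3 (0.82 log units; beyond the scatter) in this assay. For the compounds shown here, this is the first direct reading at this position, and on this single pair weaker inhibition goes with the smaller group. Compound 2 is a limit of the assay, not a number, and gives no step: the limit of > 50000 nM in this assay, at which 1 of the 3 values shown sits.

The compounds shown give no cause for the loss and do not separate the ring of 1-phenylethyl from its branched carbon. Benzyl or cyclohexyl on the same nitrogen would address that question.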